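A few compounds are considered here, and "the series" means these few. Any claim that something is new, unique, unknown or untested is made for them only; others in the source may bear on it.

Compounds measured so far:
compound 1 `OCCCCC#Cc1ccccc1C#Cc1cccc(O)c1` gives 17400 nM
compound 2 `OCCCCC#Cc1ccccc1C#Cc1cccc(C(F)(F)F)c1` gives 15300 nM
compound 3 `OCCCCC#Cc1ccccc1C#Cc1ccc(O)cc1` gives 16800 nM

All three were tested in a functional assay on DU-145 cells (Homo sapiens) for cytotoxicity; a higher number here means a weaker inhibitor of growth, a lower number a stronger inhibitor of growth. Compound 1 and compound 2 differ by trifluoromethyl in place of hydroxy on an aromatic carbon and the step is a 1.1-fold lower number from compound 1 to compound 2 (0.06 log units; within the scatter). The cores of compound 1 and compound 3 differ by 4-hydroxyphenyl in place of 3-hydroxyphenyl on a triple-bonded carbon, and the step there is a 1.0-fold lower number from compound 1 to compound 3 (0.02 log units; within the scatter). Within the data shown here, compound 2 and compound 3 have no step worked out between them; their two values lie close together and fall within the scatter of each other.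

Compound 4 `OCCCCC#Cc1ccccc1C#Cc1ccc(C(F)(F)F)cc1` has not yet been measured in this assay. It differs from compound 3 by trifluoromethyl in place of hydroxy on an aromatic carbon. Among the measured compounds shown here, this is the same kind of change as the one from compound 1 to compound 2, not the same one: in compound 2 the trifluoromethyl sits meta to a large group, in compound 4 it sits para to a large group. Since the earlier step was a 1.1-fold lower number from compound 1 to compound 2 (0.06 log units; within the scatter), the step from compound 3 to compound 4 is expected to be small as well, about a 1.1-fold lower number from compound 3 to compound 4 (0.03 log units; within the scatter). The estimate for compound 4 in this assay is 15500 nM, between 7000 nM and 35000 nM.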

Compound 4, concentration for 50% growth inhibition: 15800 nM
Compound 4: middle estimate off by 1.0-fold (0.01 log units), on the low side; the measured number falls inside the stated range.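

In this assay, trifluoromethyl in place of hydroxy, para to a large group in compound 4, gives a 1.1-fold lower number from compound 3 to compound 4 (0.03 log units; within the scatter), and the same change on the core of compound 1 reads much the same: the same change on two cores in this assay, a 1.1-fold lower number (0.06 log units; within the scatter) from compound 1 to compound 2 and a 1.1-fold lower number (0.03 log units; within the scatter) from compound 3 to compound 4, 1.1-fold (0.03 log units) apart, within the scatter of two such steps. On these two cores, then, the change carries over in the plain sense that neither step moves the number beyond the scatter. What carries over is the absence of a readable effect, not a shift with a measured size or direction, and two cores on which nothing moves cannot show how the change would behave on a core where it does have an effect.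

The compounds shown leave open whether an amine or a carboxylic acid on that aromatic carbon would move the number in this assay, and whether a longer chain in place of the one ending in hydroxy would do so. They also leave open whether the same change reads alike in any other cell line.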